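Cyclopentyl in Place of Ethyl on the Piperazine Nitrogen

The compounds below may be only part of what the source reports. "The series", "measured", "known", "first", "only" and "open" are said of these compounds alone.

Of the compounds shown here, two have so far been measured in an ADME assay on microsomes from liver (Homo sapiens) for metabolic stability, read by LC-MS, with a stated time of 60 min; a higher number here means that the compound lasts longer, a lower number that the compound disappears faster. Compound 1 `CCN1CCN(CCCn2cnc3c(N4CCN(CC)CC4)ncnc32)CC1` gives 1.51 h. Compound 2 `CCN1CCN(c2nc(NCc3ccc(F)cc3)nc3c2ncn3CCCN2CCCC2)CC1` gives 0.585 h, the lower of the two numbers, and the gap from compound 1 lies beyond the usual scatter. Within the data shown here, no single structural step connects compound 1 and compound 2, so their values can only be set side by side.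

Compound 3 `Fc1ccc(CNc2nc(N3CCN(C4CCCC4)CC3)c3ncn(CCCN4CCCC4)c3n2)cc1` has not yet been measured in this assay. It differs from compound 2 in one place: cyclopentyl in place of ethyl on an amine nitrogen in a ring. Cut one bond further out, the difference reads 4-ethylpiperazin-1-yl to 4-cyclopentylpiperazin-1-yl.

Among the measured compounds shown here, nothing among the measured compounds bears on a change of this kind, so the expectation rests on compound 2 alone. The step from compound 2 to compound 3 is expected to be a small downward one, a 1.4-fold lower number from compound 2 to compound 3 (0.14 log units; within the scatter), not clearly beyond the scatter. Compound 3 is therefore estimated to give 0.42 h in this assay, with a range from 0.2 h to 0.9 h.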

Compound 3, half-life: 0.298 h
Beside the measured number, compound 3's estimate is 1.4-fold (0.15 log units) above it, and the stated range covers the measured number.
By their numbers in this assay, from the lowest: compounds 3 and 2 (each within the scatter of the next); then compound 1.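

Among these compounds, the step from ethyl to cyclopentyl is the first single change in this assay that can be read directly, and it gives a 2.0-fold lower number from compound 2 to compound 3 (0.29 log units; within the scatter). On this amine nitrogen in a ring, a five-membered carbon ring can therefore take the place of an open ethyl group without a change that stands clear of repeated measurement, so this pair does not separate 4-ethylpiperazin-1-yl from 4-cyclopentylpiperazin-1-yl. Nothing measured here accounts for the size or direction of the printed step, and no cause can be assigned to it.

From the compounds shown here alone, it remains open how this nitrogen would fare with a group of another kind, such as methyl, cyclopropyl, an acetyl group, or a tetrahydropyran-4-yl ring that brings an oxygen atom into the substituent, and whether any of these would move the half-life beyond the scatter in this assay. Also open, going by these compounds, is whether the exchange of ethyl for cyclopentyl would read the same way on the piperazine nitrogens of compound 1, where the rest of the structure differs from that of compound 2 and compound 3.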